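Methoxy to Methylsulfanyl on a Shared Dihydropyrimidine-Type Core

The source may report more compounds than this note shows. Statements on the series, on what has been measured and on what is new or still open speak of the compounds shown alone.

Measured compounds:
compound 1, `CCOC(=O)C1=C(C)NC(=O)NC1c1ccc(O)c(O)c1`: 34 ug/mL
compound 2, `CCOC(=O)C1=C(C)NC(=O)NC1c1ccc(O)cc1`: 40.6 ug/mL
compound 3, `CCOC(=O)C1=C(C)NC(=S)NC1c1ccc(OC)cc1`: 31.4 ug/mL

The three measured compounds were tested in a functional assay on NCI-H460 cells (Homo sapiens) for inhibition, read by sulforhodamine B assay, with a stated time of 48 h; on this read-out lower numbers stand for stronger inhibition of growth and higher numbers for weaker inhibition of growth. In this assay, within the data shown here, compound 1 gives 34 ug/mL and compound 2 gives 40.6 ug/mL; the one single-point step, a 1.2-fold higher number from compound 1 to compound 2 (0.08 log units; within the scatter), is within the scatter. Compound 3 gives 31.4 ug/mL, the lowest of the three numbers, yet its gap to compound 1 and to compound 2 is also within the scatter, so the three stand as a tight group with no ranking among them.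

Compound 4, `CCOC(=O)C1=C(C)NC(=S)NC1c1ccc(SC)cc1`, differs from compound 3 by one change: methylsulfanyl in place of methoxy on an aromatic carbon. No measured step touches this swap; the only step shown, from compound 1 to compound 2, concerns a hydroxy group and is itself within the scatter. All three measured numbers lie close together. Compound 4 is therefore expected to show a 1.0-fold lower number from compound 3 to compound 4 (0.02 log units; within the scatter), no step beyond the scatter. Compound 4 is estimated at 30 ug/mL, with a range from 15 ug/mL to 60 ug/mL.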

Compound 4, concentration for 50% growth inhibition: 21.6 ug/mL
Beside the measured number, compound 4's estimate is 1.4-fold (0.14 log units) above it; the measured number falls inside the stated range.
By their numbers in this assay, from the lowest: compounds 4, 3, 1 and 2 (each within the scatter of the next).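

In this assay, among these compounds, the exchange of methoxy for methylsulfanyl on the aromatic carbon para to a large group gives a 1.5-fold lower number from compound 3 to compound 4 (0.16 log units; within the scatter) and so adds a first reading of sulfur in place of oxygen at this position. The earlier compounds shown here carried only oxygen-linked groups here, whereas this pair shows that the swap leaves the number inside what repeated measurements could give. Nothing available here bears on why the number for compound 4 falls where it does.

Going by these compounds, it remains open whether an amine, a carboxylic acid or a longer chain such as butoxy at this position would take the number beyond the scatter. On these data alone, it is also open whether the same exchange would read alike on the core of compound 1, which carries a carbonyl where compound 4 carries a thiocarbonyl.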